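The compounds below may be only part of what the source reports. "The series", "measured", "known", "first", "only" and "open" are said of these compounds alone.

Measured so far in an ADME assay on a cell-free system (plasma, Homo sapiens); on this read-out lower numbers stand for a smaller free fraction and higher numbers for a larger free fraction:
- compound 1 `CC(=O)Nc1cc(-c2ccc(N(C)C(=O)c3c(F)cccc3Cl)c(N3CC4CC4C3)c2)n(C2CCCC2)n1`: 0.002
- compound 2 `CC(=O)Nc1cc(-c2cnc(N(C)C(=O)c3c(F)cccc3Cl)c(N3CCCCC3)c2)n(C(C)C)n1`: 0.076

Not yet measured: compound 3 `CC(=O)Nc1cc(-c2ccc(N(C)C(=O)c3c(F)cccc3Cl)c(N3CC4CC4C3)c2)n(CC2CC2)n1`.

In this assay compound 1 gives 0.002, the lower of the two numbers. Compound 2 gives 0.076, and the gap between the two lies beyond the scatter.

The next comparison is the step from compound 1 to compound 3, which carries cyclopropylmethyl in place of cyclopentyl on an aromatic nitrogen. The rest of the structure stays the same.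

Among the measured compounds shown here, no pair of measured compounds isolates this change, so the data give no direct size for it. For the measured compounds named here, the expectation therefore rests on a single exchange at one place, starting from compound 1 at 0.002, with compound 2 at 0.076 as the only higher number. A small rise in the unbound fraction is expected, not a gap of the kind seen between the two measured compounds. The expected step is a 2.0-fold higher number from compound 1 to compound 3 (0.30 log units; within the scatter). For compound 3 the estimated value is 0.004, with an expected range of 0.002 to 0.009.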

Compound 3, unbound fraction: 0.005
Estimate against measurement, compound 3: 1.3-fold (0.10 log units) below; measured number inside the range.
By their numbers in this assay, from the lowest: compound 1; then compound 3; then compound 2.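

In this assay, among the compounds shown here, the group on the aromatic nitrogen proves to be a place where a single exchange moves the read-out: cyclopropylmethyl in place of cyclopentyl gives a 2.5-fold higher number from compound 1 to compound 3 (0.40 log units; beyond the scatter) with the rest of the structure unchanged, the first directly measured step. The exchange involves carbon only, going from 5 heavy atoms to 4 and from a five-membered to a three-membered non-aromatic ring, with 0 hydrogen-bond donors, 0 hydrogen-bond acceptors and no net charge on either group, so a change of this kind is enough to shift the unbound fraction beyond the scatter. The data offer no evidence that explains the rise.

Heavy-atom count and ring size change together in this one step, so the compounds shown do not separate them, and a butyl chain on the same nitrogen would be a direct test. Going by these compounds, how the unbound fraction responds to an amine or a carboxylic acid at this place also remains open.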